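A few compounds are considered here, and "the series" means these few. Any claim that something is new, unique, unknown or untested is made for them only; others in the source may bear on it.

The shared core of compound 1 `Cc1n[nH]c(C(=O)O)c1Cc1ccc(Oc2ccccc2)cc1` is a small aromatic ring carrying an acid, and from it hangs a benzyl arm that ends in a phenoxy group. In an assay on isolated protein for inhibition of 2-Hydroxyacid oxidase 2 (Homo sapiens), tested at 1 uM (a lower number here means a weaker effect, a higher number a stronger effect of the compound at the concentration tested), compound 1 gives 10%. Compound 2 `Cc1n[nH]c(C(=O)NS(C)(=O)=O)c1Cc1cccc(-c2ccc(F)cc2)c1` keeps that core but swaps the acid for an acyl sulfonamide and moves to a fluorophenyl arm; in this assay compound 2 gives 8%. Of the two numbers, compound 1's is the upper one, but the gap to compound 2 lies within the usual scatter, so neither compound is set apart from the other, and both sit near the bottom of what this read-out can show.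

Compound 3 `Cc1n[nH]c(C(=O)O)c1Cc1ccc(C(N)=O)cc1` keeps the acid and the benzyl arm of compound 1 and alters only the far end: carbamoyl in place of phenoxy on an aromatic carbon. Among the compounds with values here, no measured pair shows what such a swap does here, so the expectation rests on the weak signal of compound 1. The step from compound 1 to compound 3 in this assay is expected to be small, a number 4 percentage points lower from compound 1 to compound 3 (within the scatter), not beyond the scatter in either direction. Compound 3 is therefore estimated at 6%, with a range from -8% to 20%.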

Compound 3, a percentage reported as inhibition, at one concentration (the size of the read-out at that concentration, not a potency): 0%
The estimate for compound 3 lay 6 percentage points above the measured number; the range from low to high includes it.
By their numbers in this assay, from the lowest: compounds 3, 2 and 1 (each within the scatter of the next).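

Carbamoyl in place of phenoxy on an aromatic carbon gives, in this assay, a number 10 percentage points lower from compound 1 to compound 3 (within the scatter) and this is the first comparison here in which only one place differs. The change takes away a whole six-membered aromatic ring and brings in a smaller group with a hydrogen-bond donor, yet the two compounds cannot be told apart in this read-out. At this position, then, two very different groups both give numbers near the bottom of what the read-out can show, so neither the phenoxy ring nor the carbamoyl stands out as making a measurable difference, and no measurement here offers a reason for this result.

From the compounds shown here alone, with both numbers so low, it remains open whether any group on this aromatic carbon can lift the read-out clearly above the scatter. An amine, a methoxy group or a longer carbon chain at this place could test that, and only a compound with a clearly higher number would show how much this position matters.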